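The compounds below may be only part of what the source reports. "The series", "measured", "known", "first", "only" and "open" are said of these compounds alone.

compound 1 `CCOc1c(-c2cc(OC)c(OC)c(OC)c2)oc2ccccc2c1=O`: 5400 nM
compound 2 `CCCOc1c(-c2cc(OC)c(OC)c(OC)c2)oc2ccccc2c1=O`: 5700 nM
compound 3 `CCN(CC)CCCCOc1c(-c2cc(OC)c(OC)c(OC)c2)oc2ccccc2c1=O`: 13500 nM

These values come from a functional assay on LNCaP cells (Homo sapiens) for antiproliferative activity, read by WST assay, with a stated time of 3 days; on this read-out lower numbers stand for stronger inhibition and higher numbers for weaker inhibition. Compound 3 has the highest number of the three. The steps that lead to it are a 2.5-fold higher number from compound 1 to compound 3 (0.40 log units; beyond the scatter) and a 2.4-fold higher number from compound 2 to compound 3 (0.37 log units; beyond the scatter), both modest but beyond the scatter. The remaining step, a 1.1-fold higher number from compound 1 to compound 2 (0.02 log units; within the scatter), lies within the scatter.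

Compound 4 `CCCCCN(CCCCC)CCCCCOc1c(-c2cc(OC)c(OC)c(OC)c2)oc2ccccc2c1=O` is the next to be measured, and its difference is (dipentylamino)methyl in place of diethylamino on a saturated chain carbon, four bonds along the chain from an oxygen on an aromatic ring. In short, (dipentylamino)methyl stands in place of diethylamino on a saturated chain carbon, four bonds along the chain from an oxygen on an aromatic ring.

Within the data shown here, no measured step exchanges one amine for another, so the evidence is indirect. The closest guides are the two modest steps to compound 3, which show how far an amine-bearing chain has moved the number in this small set. The small alkyl change, a 1.1-fold higher number from compound 1 to compound 2 (0.02 log units; within the scatter), gives no sign of a trend. A modest step is therefore expected in this assay, leaning tentatively toward a lower number, though the direction is poorly supported. The expected change is a 1.7-fold lower number from compound 3 to compound 4 (0.23 log units; within the scatter). Compound 4 is estimated at 8000 nM, with an expected range from 2500 nM to 22000 nM.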

Compound 4, half-maximal inhibitory concentration: 7900 nM
For compound 4 the middle estimate is 1.0-fold (0.01 log units) above the measured one, within the range that was stated.
By their numbers in this assay, from the lowest: compounds 1, 2, 4 and 3 (each within the scatter of the next, the first and the last beyond it).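

In this assay, placing (dipentylamino)methyl in place of diethylamino on a saturated chain carbon, four bonds along the chain from an oxygen on an aromatic ring, gives a 1.7-fold lower number from compound 3 to compound 4 (0.23 log units; within the scatter). This is the first step among these compounds that exchanges one amine-bearing group for another, rather than adding an amine-bearing group or a methyl, and it shows that a group of 12 heavy atoms can replace one of 5 at this position without a change beyond the scatter. The information available offers no explanation of why compound 3 and compound 4 fall within the scatter of each other.

On these data alone, the step alters the chain carbon count and the alkyl groups on the nitrogen together, so the contribution of each alone remains open. As far as these compounds go, it also remains open how a piperidine or morpholine, whose nitrogen sits in a ring, or a carboxylic acid would behave at the end of the chain, since both groups compared here are open-chain amines.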